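The source may report more compounds than this note shows. Statements on the series, on what has been measured and on what is new or still open speak of the compounds shown alone.

Measured so far:
- compound 1, `Cc1cc(-c2cccc(F)c2)c2ncc(CSCCc3ccccc3)n2c1`: 20 ug/mL
- compound 2, `COc1ccc(-c2cc(C)c3ncc(CSCCc4ccccc4)n3c2)cc1`: 20 ug/mL

Both compounds were run in an ADME assay on HEL cells (Homo sapiens) for cytotoxicity, with a stated time of 3 days; a higher number here means that more compound is tolerated, a lower number that less compound is tolerated. Compound 1 gives 20 ug/mL. Compound 2 gives 20 ug/mL. On the digits shown compound 1 stands level with compound 2, and the two values lie within the scatter of each other, so nothing can be said about an order between them.

Compound 3, `COc1ccc(-c2cc(C)cn3c(CSCCc4ccccc4)cnc23)cc1`, has not been measured in this assay. It differs from compound 1 in one place: 4-methoxyphenyl in place of 3-fluorophenyl on an aromatic carbon. Going by the values given here, no step between two measured compounds isolates this change on the core of compound 1. The nearest pointer is compound 2, which carries the same 4-methoxyphenyl group on a differently built core and gives 20 ug/mL, no different from compound 1 within the scatter. On that basis no step beyond the scatter is expected in this assay, in either direction.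

For compound 3 the expected value in this assay is 20 ug/mL, with a range of 10 ug/mL to 45 ug/mL. The step from compound 1 to compound 3 is thus estimated as no change at the digits printed from compound 1 to compound 3 (within the scatter).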

Compound 3, minimum cytotoxic concentration: 20 ug/mL
Estimate against measurement, compound 3: no gap at the digits printed; low and high end bracket the measured number.
By their numbers in this assay, from the lowest: compounds 1, 2 and 3 (each within the scatter of the next).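

Working notes on the aryl position: the exchange of 3-fluorophenyl for 4-methoxyphenyl is now read directly on the core of compound 1, where the earlier compounds gave only an indirect pointer from a differently built core. In this assay this exchange, on the aromatic carbon ortho to a fused ring and meta to a methyl group, gives no change at the digits printed from compound 1 to compound 3 (within the scatter) and so shows no effect beyond the scatter at this position for these two aryl groups. No measured evidence bears on this result.

The step alters the place of the substituent on the phenyl ring and the substituent itself together, so a 4-fluorophenyl or 3-methoxyphenyl group would be needed to read these two changes apart. From the compounds shown here alone, both groups at this position are substituted phenyl rings, so it remains open whether an amine, a carboxylic acid or a longer chain on the same carbon would also stay within the scatter of compound 1 in this assay and how far such a group would move the minimum cytotoxic concentration.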